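The source may hold more compounds than are shown below. What is called first, only, known or untested is meant among the compounds shown, and "the series" means these compounds.

For the measured compounds named here, in an assay for inhibition of alpha-N-acetylgalactosaminidase (Gallus gallus), tested at 1000 uM (on this read-out higher numbers stand for more inhibition at the one concentration tested (going by the name of the read-out) and lower numbers for less inhibition), compound 1 `O=C(O)[C@H]1NC[C@H](O)[C@H](O)[C@H]1O` gives 21%, the highest of the three numbers so far. Compound 3 `O=C(O)[C@@H]1NC[C@@H](O)[C@H](O)[C@@H]1O` gives 10%, and the step of a number 11 percentage points lower from compound 1 to compound 3 (beyond the scatter) rests on the fact that the two compounds differ only in the configuration as drawn (the fact that compounds 1 and 3 differ only in the configuration as drawn). Compound 2 `O=C(O)[C@H]1NCC=C[C@H]1O` gives 0.2%, the furthest below compound 1.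

Compound 4 `O=C(O)[C@H]1NC[C@@H](O)[C@H](O)[C@@H]1O` has not yet been measured. It differs from compound 1 as follows: the two compounds have the same atoms and bonds and differ only in configuration as drawn: 2 of 4 stereo elements differ; a stereocentre at a saturated ring carbon is drawn S in compound 1 and R in compound 4; a stereocentre at a saturated ring carbon is drawn S in compound 1 and R in compound 4. Going by the values given here, of the measured steps, only the one from compound 1 to compound 3 bears on this change, since it too is a change of configuration alone, and it was a modest step downward. Compound 4 changes fewer stereocentres than compound 3 does, so a downward step of similar or somewhat smaller size is expected, namely a number 10 percentage points lower from compound 1 to compound 4 (within the scatter). In this assay compound 4 is therefore estimated to give 11%, with a range from 2% to 22%.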

Compound 4, a percentage reported as inhibition, at one concentration (the size of the read-out at that concentration, not a potency): 11%
Compound 4: the middle estimate sits on the measured number at the digits printed; measured number inside the range.
By their numbers in this assay, from the lowest: compounds 2, 3, 4 and 1 (each within the scatter of the next, the first and the last beyond it).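

In this assay, changing two stereocentres of the shared core gives a number 10 percentage points lower from compound 1 to compound 4 (within the scatter), so this partial change of configuration does not separate the two compounds beyond the scatter. Changing one further stereocentre, drawn R in one compound and S in the other, gives a number 1 percentage points higher from compound 3 to compound 4 (within the scatter), which is also no separation beyond the scatter. Of the configurational changes shown, only the one involving three stereocentres, a number 11 percentage points lower from compound 1 to compound 3 (beyond the scatter), lies beyond the scatter, and the new pair again isolates configuration alone: the fact that compounds 3 and 4 differ only in the configuration as drawn

The compounds shown leave open which of the two stereocentres changed in compound 4 accounts for any part of its step from compound 1, as neither is seen changed alone from compound 1. They also leave open how a methyl ester or a hydroxymethyl group in place of the carboxylic acid would read.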